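Notes on a Dimethoxyphenyl to Dihydroxyphenyl Exchange

The source may hold more compounds than are shown below. What is called first, only, known or untested is meant among the compounds shown, and "the series" means these compounds.

Measured so far:
compound 1 `COc1ccc(Oc2ccc(C(C)C)cc2-c2ccsc2S(=O)(=O)NCCNC(=S)Nc2ccc([N+](=O)[O-])cc2)cc1OC`: in an ADME assay on HEK-293T cells (Homo sapiens) for cytotoxicity, read by CCK-8 assay, with a stated time of 48 h (a higher number here means a weaker inhibitor, a lower number a stronger inhibitor), compound 1 gives 11400 nM
compound 2 `CC(C)c1ccc(Oc2ccc(O)c(O)c2)c(-c2ccsc2S(=O)(=O)NCCNC(=S)Nc2ccc([N+](=O)[O-])cc2)c1`: in this assay compound 2 gives 16300 nM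
compound 3 `COc1ccc(Oc2ccccc2-c2ccsc2S(=O)(=O)N2CCN(C(=O)Nc3ccc([N+](=O)[O-])cc3)CC2)cc1OC`: for compound 3 this assay reports only a limit, > 20000 nM

Compound 1 and compound 2 differ in one place, (3,4-dihydroxyphenyl in place of 3,4-dimethoxyphenyl on an oxygen on an aromatic ring); the step is a 1.4-fold higher number from compound 1 to compound 2 (0.16 log units; within the scatter). The core of compound 3 and the core of compound 1 differ in more than one place, and that difference is not broken down here. For compound 3 the value is a limit, not a number, and one of the three values shown sits at that limit (the limit of > 20000 nM in this assay, at which 1 of the 3 values shown sits).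

Compound 4 `O=C(Nc1ccc([N+](=O)[O-])cc1)N1CCN(S(=O)(=O)c2sccc2-c2ccccc2Oc2ccc(O)c(O)c2)CC1` is unmeasured. It carries the same change relative to compound 3 that compound 2 carries relative to compound 1, (3,4-dihydroxyphenyl in place of 3,4-dimethoxyphenyl on an oxygen on an aromatic ring), in the same place. In this assay the step is expected to be a step that the limit leaves unreadable from compound 3 to compound 4, resting on the step from compound 1 to compound 2, which stayed within the scatter a 1.4-fold higher number from compound 1 to compound 2 (0.16 log units; within the scatter), and on compound 3 standing at a limit > 20000 nM. Compound 4 is therefore estimated at 25000 nM, within 12000 nM to 60000 nM, most likely reported again only as a limit.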

Compound 4, half-maximal inhibitory concentration: > 20000 nM
Compound 4 was reported as a limit; the forecaster's own chance of this, stated with the estimate: 75%; the middle value lies beyond the limit too.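

Compound 3 and compound 4 are both reported only as limits, so no step between them can be read: the limit of > 20000 nM in this assay, at which 2 of the 4 values shown sit.

The compounds shown leave open whether 3,4-dihydroxyphenyl in place of 3,4-dimethoxyphenyl changes the cytotoxicity read-out at all on the core of compound 3, as the only readable instance of this exchange is the pair compound 1 and compound 2.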